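Swapping Chloro for Methoxy on a Nicotinic Agonist Core

The source may report more compounds than this note shows. Statements on the series, on what has been measured and on what is new or still open speak of the compounds shown alone.

Compound 2 `Clc1ccc(N2CC[C@H]3CN[C@H]3C2)cn1` gives 13 nM in a functional assay on HEK293 cells for agonist activity at Neuronal acetylcholine receptor; alpha4/beta2 (Homo sapiens), read by FLIPR; a higher number here means that more compound is needed for the effect, a lower number that less compound is needed. Among the three measured compounds, compound 2 stands second highest: compound 3 `Clc1cc(N2CC[C@H]3CN[C@H]3C2)cnc1Cl` gives 12 nM, with a 1.1-fold lower number from compound 2 to compound 3 (0.03 log units; within the scatter), and compound 1 `c1cncc(N2CC[C@H]3CN[C@H]3C2)c1` gives 71 nM, with a 5.5-fold lower number from compound 1 to compound 2 (0.74 log units; beyond the scatter). Compound 4 `COc1ccc(N2CC[C@H]3CN[C@H]3C2)cn1` differs from compound 2 by methoxy in place of chloro on an aromatic carbon. For the measured compounds named here, no measured step exchanges chloro for methoxy, so the expectation rests on the steps that place a chloro on the ring: the first, from compound 1 to compound 2, brought a modest gain, while the second added nothing beyond the scatter. Methoxy is expected to keep only part of that gain, so compound 4 is estimated at 35 nM. For compound 4 the expected range runs from 10 nM to 120 nM. That expectation amounts to a 2.7-fold higher number from compound 2 to compound 4 (0.43 log units; beyond the scatter).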

Compound 4, half-maximal effective concentration: 2200 nM
Compound 4: middle estimate off by 63-fold (1.80 log units), on the low side; the whole stated range lies below it.
By their numbers in this assay, from the lowest: compounds 3 and 2 (each within the scatter of the next); then compound 1; then compound 4.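

Methoxy in place of chloro on this carbon, next to the ring nitrogen, gives a 170-fold higher number from compound 2 to compound 4 (2.23 log units; beyond the scatter) and shows that the position separates these two groups sharply. Methoxy does more than lose the gain that chloro brought: it gives a 31-fold higher number from compound 1 to compound 4 (1.49 log units; beyond the scatter) and so ends well behind the compound with only hydrogen there. Nothing available here explains this drop. A methyl, a hydroxyl or an amine on this carbon would help show whether the oxygen of methoxy or its added carbon tracks with the loss. Going by these compounds, whether any group other than chloro can match compound 2 at this position remains open.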